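The source may hold more compounds than are shown below. What is called first, only, known or untested is meant among the compounds shown, and "the series" means these compounds.

Measured so far:
Compound 1, `COc1cc(C(=O)O[C@@H]2CCC[C@@H]3CCN(C)C[C@@H]32)cc(OC)c1OC`: 8.91
Compound 2, `COc1cc(C(=O)N[C@@H]2CCC[C@@H]3CCN(C)C[C@H]32)cc(OC)c1OC`: 8.75
Compound 3, `CN1CC[C@H]2CCC[C@@H](OC(=O)c3ccc(Cl)cc3)[C@@H]2C1`: 8.75

All three were examined in a physicochemical assay for acid dissociation. Compound 2 sits level with compound 3 at the digits shown, the two together being the lowest of the three numbers; compound 1 lies somewhat higher, yet that gap is still within the scatter of this assay, so no real ordering can be claimed among them.

Compound 4, `COc1cc(C(=O)N[C@@H]2CCC[C@@H]3CCN(C)C[C@@H]32)cc(OC)c1OC`, has not yet been measured. Compared with compound 2 it shows (the two compounds have the same atoms and bonds and differ only in configuration as drawn: 1 of 3 stereo elements differ; a stereocentre at a saturated ring carbon is drawn S in compound 2 and R in compound 4). Within the data shown here, no measured pair here isolates such a configurational change on its own, so the expectation rests on the narrow spread of the three numbers. In this assay compound 4 is expected to give 8.85, within 8.55 to 9.15, a step of a number 0.10 log units higher from compound 2 to compound 4 (within the scatter) that is expected to stay within the scatter.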

Compound 4, acid dissociation constant: 9.02
For compound 4 the middle estimate is 0.17 log units below the measured one, and the stated range covers the measured number.
By their numbers in this assay, from the lowest: compounds 2, 3, 1 and 4 (each within the scatter of the next).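

In this assay, this pair gives the first isolated view of a configurational swap at a saturated ring carbon, with a number 0.27 log units higher from compound 2 to compound 4 (within the scatter). Redrawing this stereocentre from S to R therefore produces no difference that can be told apart from ordinary measurement variation. The comparison is clean for one reason: the fact that compounds 2 and 4 differ only in the configuration as drawn.

As far as these compounds go, the other two stereocentres remain untested on their own. From the compounds shown here alone, it also remains open whether the same swap would stay within the scatter if a sulfonamide took the place of the amide.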